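The source may hold more compounds than are shown below. What is called first, only, known or untested is meant among the compounds shown, and "the series" means these compounds.

Measured in an assay for inhibition of leukotriene C4 synthase (Homo sapiens), read by LC-MS, with stated times of 15 min and 30 min; a lower number here means a stronger inhibitor, a higher number a weaker inhibitor:
Compound 1, `COc1cc(N(CC2CC2)c2ccc(Cl)c3ccccc23)cnc1C(=O)[C@H]1C[C@@H]1C(=O)O`, gives 1.41 nM.
Compound 2, `COc1cc(N(CC2CC2)c2ccc(Cl)c3ccccc23)cnc1C(=O)CCCC(=O)O`, gives 109 nM.
Compound 3, `COc1nc(C(=O)[C@@H]2C[C@H]2C(=O)O)ncc1N(CC1CC1)c1ccc(Cl)c2ccccc12`, gives 15.5 nM.

Compound 1 stands lowest of the three, and so is the strongest inhibitor shown. Compound 3, which differs in the shared core, gives the nearest higher number. Among the measured compounds shown here, the one single-point step measured, a 77-fold higher number from compound 1 to compound 2 (1.89 log units; beyond the scatter), concerns the acid-bearing side of the molecule and is large.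

Compound 4, `COc1cc(N(CC2CC2)c2ccc(F)c3ccccc23)cnc1C(=O)[C@H]1C[C@@H]1C(=O)O`, differs from compound 1 in one place: fluoro in place of chloro on an aromatic carbon. For the measured compounds named here, no measured step touches this halogen position, so nothing here tells how the number moves when chloro is exchanged for fluoro; the large step from the acid side is not a guide to it. The expectation therefore rests on the change being a single-atom swap on the aromatic ring, which is expected to give a small step, likely within the scatter or a modest move to a higher number. For compound 4 the estimate in this assay is 3 nM, with a range of 1 nM to 10 nM, which would mean an expected step of a 2.1-fold higher number from compound 1 to compound 4 (0.33 log units; beyond the scatter).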

Compound 4, half-maximal inhibitory concentration: 0.758 nM
Compound 4: middle estimate off by 4.0-fold (0.60 log units), on the high side; the whole stated range lies above it.
By their numbers in this assay, from the lowest: compounds 4 and 1 (each within the scatter of the next); then compound 3; then compound 2.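

In this assay, fluoro in place of chloro at this position, para to a large group on the aromatic ring, gives a 1.9-fold lower number from compound 1 to compound 4 (0.27 log units; within the scatter) and so leaves the two compounds indistinguishable. This position therefore accepts either halogen without a measurable change in the number, a very different picture from the acid-bearing side, where the step is a 77-fold higher number from compound 1 to compound 2 (1.89 log units; beyond the scatter) and is large. Nothing available here accounts for why the two halogens read alike.

The compounds shown leave open what a hydrogen, a bromo, a methyl or a nitrile would do at this same place. They also leave open whether fluoro in place of chloro would read the same way on the core of compound 3.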